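Replacing an Acetyl Group in a Red Cell Assay

The source may report more compounds than this note shows. Statements on the series, on what has been measured and on what is new or still open speak of the compounds shown alone.

In an ADME assay on cells (Erythrocyte, Homo sapiens), read by spectrophotometry and hemolysis, with a stated time of 24 h (a lower number here means a stronger inhibitor, a higher number a weaker inhibitor), compound 1 `CC(=O)c1ccccc1OCc1ccc2c(c1)=[N+]([O-])C(C)(C)[N+]=2[O-]` gives < 50 uM, which is a limit of the assay and not a number. Compound 2 `C/C(=N/NC(=N)N)c1ccccc1OCc1ccc2no[n+]([O-])c2c1` gives > 200 uM, and this too is a limit. The two limits do not overlap, with compound 1 on the stronger side and compound 2 on the weaker side. Neither compound has an exact value, so the starting point is only loosely fixed.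

Compound 3 `CC1(C)[N+]([O-])=c2ccc(COc3ccccc3/C=N\NC(N)=O)cc2=[N+]1[O-]` has not yet been measured. It keeps the core of compound 1 and differs in one place, on an aromatic carbon, ortho to a large group: a group of 6 heavy atoms (2 carbon, 3 nitrogen, 1 oxygen; no ring) in place of a group of 3 heavy atoms (2 carbon, 1 oxygen; no ring), on an aromatic carbon. The acetyl leaves, and a larger group without a ring enters.

Among the compounds with values here, no measured pair shows what such a swap does, so any forecast here is loose. A moderate shift toward weaker inhibition seems the likeliest outcome, though no change at all remains possible. The expected step is an at least 1.8-fold higher number from compound 1 to compound 3 (0.25 log units; that floor lies within the scatter), and it is a rough estimate. For compound 3, the expected value is 90 uM, with an estimated range from 25 uM to 300 uM.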

Compound 3, concentration for 50% inhibition: 50 uM
Estimate against measurement, compound 3: 1.8-fold (0.26 log units) above, and the stated range covers the measured number.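

In this assay compound 3 gives 50 uM as an exact number, the first among the compounds shown, so this aromatic carbon, ortho to a large group, can carry the larger group without a ring in place of the acetyl and still give a value that can be read. Compound 1 gives < 50 uM as a limit of the assay and not a number. The swap gives a number no lower from compound 1 to compound 3 (the limit leaves the size open). The size of this step cannot be read, and only its direction is known, because one end of the step rests on a limit: the limit of < 50 uM in this assay, at which 1 of the 3 values shown sits.

Going by these compounds, how much the swap weakens inhibition, if it does so at all, stays open until the acetyl compound has an exact value of its own. Also open, on these data alone, is what other groups would do on this same aromatic carbon, such as an amine, a carboxylic acid or a plain methyl, since a single replacement cannot show which part of the entering group matters for the number.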